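The compounds below may be only part of what the source reports. "The series", "measured", "known", "first", "only" and "open" are said of these compounds alone.

Three compounds sharing one core have so far been measured in a functional assay on L1210 cells (Mus musculus) for inhibition; a higher number here means a weaker inhibitor, a lower number a stronger inhibitor:

Compound 1 `OC[C@H]1OC(n2cnc3c(-c4ccco4)ncnc32)[C@H](O)[C@@H]1O` gives 2000 nM.
Compound 2 `OC[C@H]1OC(n2cnc3c(-c4ccc(O)cc4)ncnc32)[C@H](O)[C@@H]1O` gives 5000 nM.
Compound 3 `OC[C@H]1OC(n2cnc3c(-c4cc[nH]n4)ncnc32)[C@H](O)[C@@H]1O` gives 19800 nM.

Compound 3 stands highest of the three numbers in this assay. Its nearest neighbour is compound 2, its furthest is compound 1. The two steps leading to it both lie beyond the scatter: a 4.0-fold higher number from compound 2 to compound 3 (0.60 log units; beyond the scatter), and a 9.9-fold higher number from compound 1 to compound 3 (1.00 log units; beyond the scatter). The remaining step among the measured compounds is smaller: a 2.5-fold higher number from compound 1 to compound 2 (0.40 log units; beyond the scatter).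

Compound 4 `OC[C@H]1OC(n2cnc3c(-c4ccsc4)ncnc32)[C@H](O)[C@@H]1O` differs from compound 3 in one place: thiophen-3-yl in place of 1H-pyrazol-3-yl on an aromatic carbon. The step that bears most directly on this change is the one in which furan-2-yl was swapped for 1H-pyrazol-3-yl, because a 9.9-fold higher number from compound 1 to compound 3 (1.00 log units; beyond the scatter) shows how far a five-membered ring with a single hetero atom and no hydrogen-bond donor sits from the 1H-pyrazol-3-yl compound in this assay. The step from compound 2 also points the same way, since a 4.0-fold higher number from compound 2 to compound 3 (0.60 log units; beyond the scatter). Going back from 1H-pyrazol-3-yl to thiophen-3-yl, a group without a donor, compound 4 is therefore expected to give a clearly lower number, roughly a 6.6-fold lower number from compound 3 to compound 4 (0.82 log units; beyond the scatter). Compound 4 is estimated at 3000 nM, with a range from 1000 nM to 10000 nM.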

Compound 4, half-maximal inhibitory concentration: 10800 nM
Compound 4: middle estimate off by 3.6-fold (0.56 log units), on the low side, outside the stated range (above it).
By their numbers in this assay, from the lowest: compound 1; then compound 2; then compounds 4 and 3 (each within the scatter of the next).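

In this assay, within the data shown here, thiophen-3-yl in place of 1H-pyrazol-3-yl gives a 1.8-fold lower number from compound 3 to compound 4 (0.26 log units; within the scatter), so at this position on the shared core, losing the hydrogen-bond donor of the 1H-pyrazol-3-yl ring leaves compound 3 and compound 4 indistinguishable, which the earlier compounds could not show. Lacking a donor is also not enough to match furan-2-yl, as a 5.4-fold higher number from compound 1 to compound 4 (0.73 log units; beyond the scatter) shows, and compound 2, whose 4-hydroxyphenyl group carries a donor, goes against any link between a donor and a higher number, given a 2.2-fold higher number from compound 2 to compound 4 (0.33 log units; beyond the scatter). Nothing on hand accounts for why these groups differ in this way.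

The compounds shown leave open whether the hetero atom or the point of attachment separates furan-2-yl from thiophen-3-yl, as the two differ in both, and thiophen-2-yl would be the direct test of that question. They also leave open how groups other than aromatic rings behave at this position, such as an amine or a short alkyl chain on the same aromatic carbon.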